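The source may report more compounds than this note shows. Statements on the series, on what has been measured and on what is new or still open speak of the compounds shown alone.

Measured in a functional assay on 4T1 cells (Mus musculus) for cytotoxicity, read by MTT assay, with a stated time of 24 h; a lower number here means a stronger inhibitor, a higher number a weaker inhibitor:

- Compound 1 `O=C1/C(=C/c2ccccc2F)CN(Cc2cn(Cc3ccccc3F)nn2)C/C1=C\c1ccccc1F`: 6500 nM
- Compound 2 `COc1ccc(/C=C2\CN(Cc3cn(Cc4cccc(Cl)c4)nn3)C/C(=C\c3ccc(OC)cc3)C2=O)cc1`: 56600 nM
- Compound 3 `COc1ccc(/C=C2\CN(C(=S)SCc3cn(Cc4ccc(F)cc4)nn3)C/C(=C\c3ccc(OC)cc3)C2=O)cc1`: > 100000 nM (a limit of the assay, not a number)

Of the two compounds with a true number, compound 1 has the lower one, and its gap to compound 2 lies beyond the usual scatter of repeated measurements. That makes compound 1 the natural starting point for the next comparison.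

Compound 4 `O=C1/C(=C/c2ccccc2F)CN(Cc2cn(Cc3cccc(Cl)c3)nn2)C/C1=C\c1ccccc1F` keeps the core of compound 1 and alters one group, with 3-chlorophenyl in place of 2-fluorophenyl on a saturated chain carbon bound to an aromatic nitrogen. Put another way, a 2-fluorobenzyl becomes a 3-chlorobenzyl.

For the measured compounds named here, no measured pair of compounds differs in only one place, so the size of this step has no direct precedent. Compound 2, at 56600 nM, carries the same 3-chlorobenzyl, but it also differs from compound 4 elsewhere, so it offers only a weak hint towards a higher number. In this assay, no step beyond the scatter is therefore expected, only a slight lean towards weaker inhibition.

The expected change is a 1.4-fold higher number from compound 1 to compound 4 (0.14 log units; within the scatter). For compound 4 the estimated value is 9000 nM, with an expected range of 3000 nM to 27000 nM.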

Compound 4, half-maximal inhibitory concentration: 6100 nM
Compound 4: middle estimate off by 1.5-fold (0.17 log units), on the high side; measured number inside the range.
By their numbers in this assay, from the lowest: compounds 4 and 1 (each within the scatter of the next); then compound 2. At a limit, above all of these: compound 3.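

For the compounds shown here, measured in this assay the change from 2-fluorobenzyl to 3-chlorobenzyl gives a 1.1-fold lower number from compound 1 to compound 4 (0.03 log units; within the scatter) and this is the first direct reading of a single change on the saturated chain carbon bound to an aromatic nitrogen. The earlier compounds shown here could not supply such a reading, since compounds 1, 2 and 3 differ from one another in more than one place, so no gap among them could be assigned to one group. On the core of compound 1, this position accepts either of these two substituted benzyl groups with no change beyond the scatter, although nothing measured here explains why.

Going by these compounds, because the halogen and its printed ring position change together in this single step, the separate contribution of each remains unknown, and a 3-fluorobenzyl or 2-chlorobenzyl group would be needed to separate them. On these data alone, it also remains open whether a more different group at this place, such as an amine, a carboxylic acid or a longer chain in place of the benzyl, would move the number beyond the scatter.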